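Removing the fluorine from a selenocyanate carbamate

A few compounds are considered here, and "the series" means these few. Any claim that something is new, unique, unknown or untested is made for them only; others in the source may bear on it.

Measured compounds:
compound 1 `CC(C)COC(=O)Nc1ccc([Se][Se]c2ccc(NC(=O)OCC(C)C)cc2)cc1`: 9800 nM
compound 2 `N#C[Se]c1ccc(NC(=O)Oc2ccc(F)cc2)cc1`: 12600 nM
compound 3 `CCCCOC(=O)Nc1ccc([Se][Se]c2ccc(NC(=O)OCCCC)cc2)cc1`: 16700 nM

These three compounds were tested in a functional assay on CCRF-CEM cells (Homo sapiens) for cytotoxicity, read by MTT assay, with a stated time of 72 h; a higher number here means a weaker inhibitor of growth, a lower number a stronger inhibitor of growth. Compound 1 gives 9800 nM and compound 3 gives 16700 nM; both carry a diselenide linking two carbamate-bearing rings. Compound 2 is built differently, with a selenocyanate on one ring and a phenyl carbamate bearing a fluoro group, and in this assay compound 2 gives 12600 nM. This number sits among those of compound 1 and compound 3, and neither gap reaches beyond the usual scatter, so the three cannot be told apart on these numbers.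

Compound 4 `N#C[Se]c1ccc(NC(=O)Oc2ccccc2)cc1` differs from compound 2 in one place: hydrogen in place of fluoro on an aromatic carbon. Within the data shown here, no measured pair shows what such a change does in this assay, so no direction can be read from the data. The expectation is that the step from compound 2 to compound 4 stays within the scatter, a 1.0-fold higher number from compound 2 to compound 4 (0.01 log units; within the scatter). Compound 4 is therefore estimated at 13000 nM, with a range from 5000 nM to 32000 nM.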

Compound 4, concentration for 50% growth inhibition: 22900 nM
Compound 4: the middle estimate sits 1.8-fold (0.25 log units) below what was measured; measured number inside the range.
By their numbers in this assay, from the lowest: compounds 1, 2, 3 and 4 (each within the scatter of the next, the first and the last beyond it).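

Among these compounds, this is the first pair here that differs in one place only, so it gives the first direct look at this position. In this assay, hydrogen in place of fluoro on an aromatic carbon, para to a large group, gives a 1.8-fold higher number from compound 2 to compound 4 (0.26 log units; within the scatter), so on this single pair the fluoro group and hydrogen cannot be told apart at this position. No further measurement bears on this result.

What the compounds shown leave open is whether a larger or differently built group at the same place, such as chloro, methoxy, an amine or a carboxylic acid, would give a step beyond the scatter. On these data alone, it also remains open whether the same exchange would give a similar step on a compound carrying a diselenide instead of a selenocyanate.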